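Shortening a Butyl Chain: From Compound 1 to Compound 4

The source may hold more compounds than are shown below. What is called first, only, known or untested is meant among the compounds shown, and "the series" means these compounds.

Compound 1 `CCCCc1ccc(-c2cc(-c3cn([C@H]4C[C@H](OC(C)=O)[C@@H](COC(C)=O)O4)c(=O)[nH]c3=O)on2)cc1` gives 30.4% in a functional assay on PC-3 cells (Homo sapiens) for cytotoxicity, read by sulforhodamine B assay, tested at 10 uM; a lower number here means less inhibition, a higher number more inhibition at the concentration tested (going by the name of the read-out).
Compound 2 `CCCCCCCCc1cc(-c2cn([C@H]3C[C@H](O)[C@@H](CO)O3)c(=O)[nH]c2=O)on1` gives 77.3% in this assay.
Compound 3 `O=c1[nH]c(=O)n([C@H]2C[C@H](O)[C@@H](CO)O2)cc1-c1cn(Cc2ccccc2)nn1` gives 92.1% in this assay.

Compound 1 stands lowest of the three numbers in this assay; compound 2 lies higher by a margin beyond the scatter, and compound 3 higher still, also beyond the scatter. Among the measured compounds shown here, no two measured compounds differ in only one place, so no single step is available to guide the next move. Compound 4 `CCc1ccc(-c2cc(-c3cn([C@H]4C[C@H](OC(C)=O)[C@@H](COC(C)=O)O4)c(=O)[nH]c3=O)on2)cc1` differs from compound 1 by hydrogen in place of ethyl on a saturated chain carbon, two bonds along the chain from an aromatic carbon. For the measured compounds named here, with no comparable step in the data, the change is expected to shift this assay little, and a number 3.4 percentage points lower from compound 1 to compound 4 (within the scatter) is expected to stay within the scatter. Compound 4 is therefore estimated at 27%, with a range from 8% to 48%.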

Compound 4, a percentage reported as inhibition, at one concentration (the size of the read-out at that concentration, not a potency): 62.8%
The estimate for compound 4 lay 35.8 percentage points below the measured number, and the stated range ends below it.
By their numbers in this assay, from the lowest: compound 1; then compound 4; then compound 2; then compound 3.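

In this assay the change from 4-butylphenyl to 4-ethylphenyl gives a number 32.4 percentage points higher from compound 1 to compound 4 (beyond the scatter) and so shows that the number changes with the chain at this place. Among the compounds shown here, this is the first step that can be read for a single change, and removing the outer part of the chain raises the number. Nothing available accounts for the size of this step.

For the compounds shown here, only two chain lengths can be compared here, so the trend remains open. A propyl, a methyl or a longer chain such as hexyl at this place could show whether the number moves steadily with length, and a terminal amine could show whether the number is higher, lower or level with a different group at the chain end.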